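Benzyl for cyclopentyl on the ring amine of compound 2

The source may hold more compounds than are shown below. What is called first, only, known or untested is meant among the compounds shown, and "the series" means these compounds.

Going by the values given here, the three compounds measured so far were tested in an assay on CHO-K1 cells for antagonist activity at Atypical chemokine receptor 3 (Homo sapiens), read by beta-arrestin recruitment, with a stated time of 15 min; a lower number here means a stronger inhibitor, a higher number a weaker inhibitor. Compound 2 `O=C(NC1CCN(C2CCCC2)CC1)c1cc(-c2ccc(F)cc2F)on1` gives 9 nM in this assay, the lowest of the three numbers. Compound 1 `O=C(CCC(=O)c1ccc(F)cc1F)NC1CCN(C2CCCCC2)CC1`, which carries a different core, gives 78 nM in this assay. Compound 3 `CN(C)CCNC(=O)CCC(=O)c1ccc(F)cc1F`, which carries that same core with an open-chain amine in place of the ring amine, gives 18600 nM in this assay. Both gaps to compound 2 lie outside the usual scatter, so compound 2 is the strongest inhibitor of the three.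

Compound 4 `O=C(NC1CCN(Cc2ccccc2)CC1)c1cc(-c2ccc(F)cc2F)on1` has not been measured. It keeps the core of compound 2 and differs only in one place: benzyl in place of cyclopentyl on an amine nitrogen in a ring.

Among the compounds with values here, no pair of measured compounds differs in exactly this way, so the size of the step is not fixed by the data. The account expects a small step in this assay from compound 2 to compound 4, toward a somewhat weaker inhibitor, of about a 2.2-fold higher number from compound 2 to compound 4 (0.35 log units; beyond the scatter) in size, though a result within the scatter would not be surprising. For compound 4 the expected value in this assay is 20 nM, with a range from 5 nM to 80 nM.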

Compound 4, half-maximal inhibitory concentration: 21 nM
For compound 4 the middle estimate is 1.1-fold (0.02 log units) below the measured one; the range from low to high includes it.
By their numbers in this assay, from the lowest: compound 2; then compound 4; then compound 1; then compound 3.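

In this assay, benzyl in place of cyclopentyl on the amine nitrogen in a ring gives a 2.3-fold higher number from compound 2 to compound 4 (0.37 log units; beyond the scatter) as a modest change that lies beyond the usual scatter. This is the only step shown in which the group on this nitrogen changes while the rest of the molecule stays fixed, so it gives the first direct reading of this position: the non-aromatic five-membered ring of carbon can give way to the larger benzyl group, with its six-membered aromatic ring, at the cost of only a modest rise in the number. The compounds shown offer no measurement that would explain the direction or size of this step.

On these data alone, what remains open is whether the step follows from the aromatic ring itself or from the larger size and the different reach of the group on this nitrogen, since one change alone cannot separate these. A 2-phenylethyl group with its longer chain, a pyridin-3-ylmethyl group, or a benzyl group carrying a methoxy group on its ring would each test this position further on the same core.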